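Replacing the amino group on the shared core of compound 1

This account rests on a few compounds, and the source may have more. Where it says the series, first, only, none or still open, it means among the compounds named here.

The shared core is seen in compound 1 `CCOC(=O)Nc1cc2c(c(N)n1)N=C(c1ccccc1)CO2`, which in a functional assay on L1210 cells (Mus musculus) for antiproliferative activity, with a stated time of 48 h (a higher number here means a weaker inhibitor, a lower number a stronger inhibitor), gives 0.225 uM. Among the two numbers shown, compound 1 stands lowest. Compound 2 `CCOC(=O)Nc1cc2c(c(N)n1)N=C(c1ccccc1)C(c1ccccc1)O2` gives 0.88 uM, a change of a 3.9-fold higher number from compound 1 to compound 2 (0.59 log units; beyond the scatter). Compound 3 `CCOC(=O)Nc1cc2c(c(N)n1)N=C(c1ccc([N+](=O)[O-])cc1)CO2` reaches only a limit of the assay, > 3 uM, and so offers no number; the step of an at least 13-fold higher number from compound 1 to compound 3 (1.12 log units; beyond the scatter) is therefore known only as a floor, as the shared limit of > 3 uM in this assay, at which 1 of the 3 values shown sits, shows.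

Compound 4 `CCOC(=O)Nc1cc2c(c(/N=C/N(C)C)n1)N=C(c1ccccc1)CO2` carries a different change: a group of 5 heavy atoms (3 carbon, 2 nitrogen; no ring) in place of one nitrogen atom, on an aromatic carbon, on the carbon next to the ring nitrogen, ortho to a fused ring and meta to the (ethoxycarbonyl)amino group. Neither measured step touches this position, so neither bears on it directly; both, however, added atoms to compound 1 and both raised the number, one modestly and one at least largely. A modest rise is therefore expected for compound 4, estimated as a 2.2-fold higher number from compound 1 to compound 4 (0.35 log units; beyond the scatter), giving an expected value of 0.5 uM, within a range from 0.15 uM to 2 uM.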

Compound 4, concentration for 50% inhibition: 0.31 uM
Estimate against measurement, compound 4: 1.6-fold (0.21 log units) above, and the stated range covers the measured number.
By their numbers in this assay, from the lowest: compounds 1 and 4 (each within the scatter of the next); then compound 2. At a limit, above all of these: compound 3.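

At the aromatic carbon next to the ring nitrogen, the amino group gives way to a group of 5 heavy atoms with a step of a 1.4-fold higher number from compound 1 to compound 4 (0.14 log units; within the scatter) in this assay. The two earlier steps, made elsewhere on the shared core, both lay beyond the scatter, so added atoms do not raise the number in every place, and the entering group holds up here although it has no hydrogen-bond donor. Nothing shown gives a reason for this result.

Going by these compounds, whether this tolerance extends to other replacements at this position stays open, for a smaller methylamino group, an acetamido group or plain hydrogen alike. Also open, on these data alone, is whether the phenyl and nitro changes would have the same effect in the presence of the new group.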